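This account rests on a few compounds, and the source may have more. Where it says the series, first, only, none or still open, it means among the compounds named here.

Compound 1 `NC(=O)c1cc(Cl)c2c(Cl)c(C#CCCO)n([C@H]3CCCNC3)c2n1` gives the lowest of the two single numbers recorded in a functional assay on KG-1 cells (Homo sapiens) for antiproliferative activity (on this read-out lower numbers stand for an effect already at smaller amounts and higher numbers for an effect only at larger amounts of compound), namely 56 nM. Compound 2 `CC1(CC#Cc2c(Cl)c3c(Cl)cc(C(N)=O)nc3n2[C@H]2CCCNC2)COC1` gives 289 nM in this assay. Compound 3 `NC(=O)c1cc(Cl)c2c(Cl)c(C#CC3COCCO3)n([C@H]3CCCNC3)c2n1` has been run more than once in this assay and gives 77 nM; 203 nM (2 entries), so it has no single number; the spread between its entries the several entries of compound 3 in this assay, 77 nM; 203 nM (2 entries) shows how far repeated runs of the same compound can drift. Among the compounds with values here, the one step between measured compounds, a 5.2-fold higher number from compound 1 to compound 2 (0.71 log units; beyond the scatter), comes from putting 3-methyloxetan-3-yl in place of hydroxymethyl on a saturated chain carbon bound to a triple-bonded carbon.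

Compound 4 `CN1CC(C#Cc2c(Cl)c3c(Cl)cc(C(N)=O)nc3n2[C@H]2CCCNC2)CC1=O` differs from compound 1 by 1-methyl-5-oxopyrrolidin-3-yl in place of 2-hydroxyethyl on a triple-bonded carbon. Within the data shown here, this change, like the one from compound 1 to compound 2, exchanges a short hydroxyl-bearing chain for a small saturated ring, so a step in the same direction, toward a higher number, is expected, of roughly similar or somewhat smaller size, a 2.9-fold higher number from compound 1 to compound 4 (0.46 log units; beyond the scatter). Compound 4 is therefore estimated at 160 nM in this assay, within a range of 55 nM to 480 nM.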

Compound 4, half-maximal effective concentration: 155 nM
Compound 4: the middle estimate sits 1.0-fold (0.01 log units) above what was measured, within the range that was stated.
By their numbers in this assay, from the lowest: compound 1; then compounds 4 and 2 (each within the scatter of the next).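

Placing 1-methyl-5-oxopyrrolidin-3-yl on the triple-bonded carbon in place of 2-hydroxyethyl gives a 2.8-fold higher number from compound 1 to compound 4 (0.44 log units; beyond the scatter), so a second ring-bearing group also ends with a higher number than the open hydroxyl chain. The two ring-bearing groups cannot be told apart, as the remaining step is a 1.9-fold lower number from compound 2 to compound 4 (0.27 log units; within the scatter), even though one ring sits directly on the triple-bonded carbon and the other is set one chain carbon further out. Compound 3 also carries a ring at this place but cannot be counted for or against this pattern, as it has no single number: the several entries of compound 3 in this assay, 77 nM; 203 nM (2 entries)

Going by these compounds, it remains open whether the hydroxyl group or the open chain itself goes with the low number of compound 1. A plain butyl chain, or a chain ending in an amine, on the same triple-bonded carbon would help separate the two.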